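Series notes: from compound 3 to compound 4

The source may hold more compounds than are shown below. What is called first, only, known or untested is meant among the compounds shown, and "the series" means these compounds.

Three measured compounds share one core and differ only in the group on a six-membered aromatic ring. Compound 1 `COc1ccc(CO/N=C/c2c(C)nn(C)c2Oc2ccc(Cl)cc2)cc1` gives 37% in a functional assay on MCF7 cells (Homo sapiens) for antiproliferative activity, tested at 1 uM; a lower number here means less inhibition, a higher number more inhibition at the concentration tested (going by the name of the read-out). Compound 2 `Cc1ccc(CO/N=C/c2c(C)nn(C)c2Oc2ccc(Cl)cc2)cc1` gives 30.7% in this assay, and compound 3 `Cc1nn(C)c(Oc2ccc(Cl)cc2)c1/C=N/OCc1ccc(C(F)(F)F)cc1` gives 16.4%. Compound 3 thus holds the lowest of the three numbers: the step of a number 20.6 percentage points lower from compound 1 to compound 3 (beyond the scatter) and the step of a number 14.3 percentage points lower from compound 2 to compound 3 (beyond the scatter) both lie beyond the scatter, whereas the step of a number 6.3 percentage points lower from compound 1 to compound 2 (within the scatter) does not.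

Compound 4 `COC(=O)c1ccc(CO/N=C/c2c(C)nn(C)c2Oc2ccc(Cl)cc2)cc1` is not yet measured. Its change from compound 3 is methoxycarbonyl in place of trifluoromethyl on an aromatic carbon. Going by the values given here, no measured step introduces methoxycarbonyl, so the steps that bear on it are those that placed trifluoromethyl on this carbon, a number 20.6 percentage points lower from compound 1 to compound 3 (beyond the scatter) and a number 14.3 percentage points lower from compound 2 to compound 3 (beyond the scatter). Both show that exchanging the group at this position shifts the read-out by a modest amount at most, and that trifluoromethyl gave the lowest value of the three. Replacing trifluoromethyl with another group is therefore expected to move this assay upward by a modest step or to leave it within the scatter; a fall further below compound 3 is not indicated. Compound 4 is expected to give about 25%, within 10% to 42%. That corresponds to an expected step of a number 8.6 percentage points higher from compound 3 to compound 4 (within the scatter).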

Compound 4, a percentage reported as inhibition, at one concentration (the size of the read-out at that concentration, not a potency): 33.6%
Estimate against measurement, compound 4: 8.6 percentage points below; low and high end bracket the measured number.
By their numbers in this assay, from the lowest: compound 3; then compounds 2, 4 and 1 (each within the scatter of the next).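

Exchanging trifluoromethyl for methoxycarbonyl on this aromatic carbon gives a number 17.2 percentage points higher from compound 3 to compound 4 (beyond the scatter) in this assay, so the low number of compound 3 now stands apart from a third group as well as from methyl and methoxy. Methoxycarbonyl itself does not separate from those two groups: the steps of a number 2.9 percentage points higher from compound 2 to compound 4 (within the scatter) and a number 3.4 percentage points lower from compound 1 to compound 4 (within the scatter) leave compound 1, compound 2 and compound 4 as one level in this assay, with only trifluoromethyl set off from the rest. Trifluoromethyl and methoxycarbonyl have the same heavy-atom count, so that count alone does not separate them, and nothing available gives a reason for the step.

On these data alone, whether a carboxylic acid or a primary amide on this carbon would stay level with compound 4 remains open, as does whether the low number of compound 3 extends to another fluorine-bearing group such as trifluoromethoxy. As far as these compounds go, with a single tested concentration, how these numbers would relate to potency also stays open.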